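Amine substitution in the series: allylamino to diethylamino

The compounds below may be only part of what the source reports. "The series", "measured", "known", "first", "only" and "open" are said of these compounds alone.

- compound 1 `CCC(=O)N(c1ccc(Cl)c(Cl)c1)C1CCCC1N`: 0.8 mg/kg
- compound 2 `C=CCNC1CCCC1N(C(=O)CC)c1ccc(Cl)c(Cl)c1`: 3 mg/kg

Going by the values given here, in a functional assay on the whole organism for antagonist activity, with Mus musculus as the target (on this read-out lower numbers stand for an effect already at smaller amounts and higher numbers for an effect only at larger amounts of compound), compound 2 holds the higher of the two numbers at 3 mg/kg, and compound 1 is its only neighbour. The next structure is compound 3 `CCC(=O)N(c1ccc(Cl)c(Cl)c1)C1CCCC1N(CC)CC`, with diethylamino in place of allylamino on a saturated ring carbon. Among the compounds with values here, only one measured step bears on this change: a 3.8-fold higher number from compound 1 to compound 2 (0.57 log units; beyond the scatter). That step, modest in size, put allyl in place of hydrogen on an amine nitrogen. Within the data shown here, no measured compound carries diethylamino, so the transfer from that step is uncertain. In this assay the expected change is again toward a higher number and no larger than the measured step, estimated as a 1.7-fold higher number from compound 2 to compound 3 (0.22 log units; within the scatter). The estimate for compound 3 is 5 mg/kg, with an expected range from 1.5 mg/kg to 18 mg/kg.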

Compound 3, dose for half-maximal effect: 0.03 mg/kg
The estimate for compound 3 lay 170-fold (2.22 log units) above the measured number, and the stated range ends above it.
By their numbers in this assay, from the lowest: compound 3; then compound 1; then compound 2.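

At this saturated ring carbon, substitution on the amine nitrogen does not act in one direction in this assay: allyl brought a 3.8-fold higher number from compound 1 to compound 2 (0.57 log units; beyond the scatter) while diethylamino brings a 100-fold lower number from compound 2 to compound 3 (2.00 log units; beyond the scatter) and a 27-fold lower number from compound 1 to compound 3 (1.43 log units; beyond the scatter) on the same nitrogen. The allyl step therefore did not set the trend for this position, and compound 3 now holds the lowest number of the three, with both of its steps beyond the scatter. Nothing measured here accounts for this reversal.

Diethylamino enters with 0 hydrogen-bond donors where allylamino carries 1, and the compounds shown do not separate that difference from the presence of the two ethyl chains. Ethylamino, dimethylamino and dipropylamino at this carbon remain open, so it is unknown how far the low number depends on the exact amine.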